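The compounds below may be only part of what the source reports. "The series", "measured", "known", "first", "only" and "open" are said of these compounds alone.

Working notes on the series

The three measured compounds share one core and differ only in the group on the saturated chain carbon bound to the aromatic nitrogen. Compound 1 `CCn1nc(-c2cccnc2)c2ccccc2c1=O` carries a plain ethyl there and in an assay on isolated protein (Oryctolagus cuniculus) with Thromboxane-A synthase (Homo sapiens) as the target, tested at 1 uM (a lower number here means less inhibition, a higher number more inhibition at the concentration tested (going by the name of the read-out)), compound 1 gives 87%. Compound 2 `O=c1c2ccccc2c(-c2cccnc2)nn1CCSc1nccs1` carries the (1,3-thiazol-2-yl)sulfanyl on that chain and in this assay compound 2 gives 97%; the step of a number 10 percentage points higher from compound 1 to compound 2 (within the scatter) is within the scatter. Compound 3 `O=c1c2ccccc2c(-c2cccnc2)nn1CCO` carries the hydroxy on the chain and in this assay compound 3 gives 69%, the lowest of the three numbers: a number 18 percentage points lower from compound 1 to compound 3 (beyond the scatter) and a number 28 percentage points lower from compound 2 to compound 3 (beyond the scatter) both lie beyond the scatter.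

Compound 4 `O=C(O)c1ccc(Cn2nc(-c3cccnc3)c3ccccc3c2=O)cc1` is not yet measured. Its change from compound 3 is 4-carboxyphenyl in place of hydroxymethyl on a saturated chain carbon bound to an aromatic nitrogen. The two steps that bear on it are those onto compound 3, which show that the hydroxy on the chain goes with the lowest number in this assay, and that both a plain chain and a chain bearing a larger group stand higher. The change to compound 4 takes the hydroxy away and brings in a larger group, so the expected step is a number 19 percentage points higher from compound 3 to compound 4 (beyond the scatter). For compound 4 the expected value in this assay is 88%, with a range from 74% to 98%.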

Compound 4, a percentage reported as inhibition, at one concentration (the size of the read-out at that concentration, not a potency): 64%
Compound 4: middle estimate off by 24 percentage points, on the high side; the whole stated range lies above it.
By their numbers in this assay, from the lowest: compounds 4 and 3 (each within the scatter of the next); then compounds 1 and 2 (each within the scatter of the next).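

In this assay, 4-carboxyphenyl in place of hydroxymethyl gives a number 5 percentage points lower from compound 3 to compound 4 (within the scatter), so at this position the larger group does not separate itself from the hydroxy-bearing chain. Against the other two chains, 4-carboxyphenyl in place of ((1,3-thiazol-2-yl)sulfanyl)methyl gives a number 33 percentage points lower from compound 2 to compound 4 (beyond the scatter), and 4-carboxyphenyl in place of methyl gives a number 23 percentage points lower from compound 1 to compound 4 (beyond the scatter); the four compounds therefore fall into a lower pair, compound 3 and compound 4, and a higher pair, compound 1 and compound 2, and the size of the group alone does not decide the pair, since compound 2 and compound 4 both carry large groups yet stand apart. No measurement shown here accounts for this split between the pairs.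

The compounds shown leave open whether the lower number of compound 4 goes with the carboxylic acid or with the benzene ring that carries it, which a plain benzyl group or the methyl ester of the acid on the same carbon would address. From the compounds shown here alone, it also remains open whether a carboxylic acid at the end of a longer saturated chain, without the ring, would fall with the lower pair.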